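Lengthening the Ester Chain on Compound 3

The source may report more compounds than this note shows. Statements on the series, on what has been measured and on what is new or still open speak of the compounds shown alone.

Compound 1 `COc1cc(/C=C/C(=O)c2cccc(NC(=O)c3ccco3)c2)ccc1O`: 5.46 ug/mL in a functional assay on B16 cells (Mus musculus) for inhibition; a lower number here means a stronger inhibitor, a higher number a weaker inhibitor.
Compound 2 `COc1cc(/C=C/C(=O)c2cccc(N)c2)ccc1O`: 11.5 ug/mL in this assay.
Compound 3 `COC(=O)C(=O)Nc1cccc(C(=O)/C=C/c2ccc(O)c(OC)c2)c1`: 4.41 ug/mL in this assay.

Compound 3 has the lowest of the three numbers, but its lead is uneven: the step of a 1.2-fold lower number from compound 1 to compound 3 (0.09 log units; within the scatter) is within the scatter, so compounds 1 and 3 cannot be told apart, while the step of a 2.6-fold lower number from compound 2 to compound 3 (0.42 log units; beyond the scatter) is beyond it, so compound 3 is clearly separated from compound 2 alone. The step of a 2.1-fold higher number from compound 1 to compound 2 (0.32 log units; beyond the scatter) shows that removing the whole group from the ring nitrogen weakens inhibition modestly.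

Compound 4 `CCOC(=O)C(=O)Nc1cccc(C(=O)/C=C/c2ccc(O)c(OC)c2)c1` differs from compound 3 in one place: methyl in place of hydrogen on a saturated chain carbon bound to an oxygen next to a carbonyl group. Going by the values given here, no measured pair touches this position. The nearest guide is the step of a 1.2-fold lower number from compound 1 to compound 3 (0.09 log units; within the scatter), where exchanging the entire group on the carbonyl carbon barely moved the number; a single added methyl on the ester oxygen is a far smaller change than that. The expectation is therefore a step of a 1.0-fold higher number from compound 3 to compound 4 (0.01 log units; within the scatter) in this assay, that is, no change beyond the scatter. Compound 4 is estimated at 4.5 ug/mL, with a likely range from 2.5 ug/mL to 8.5 ug/mL.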

Compound 4, half-maximal inhibitory concentration: 7.03 ug/mL
For compound 4 the middle estimate is 1.6-fold (0.19 log units) below the measured one, and the stated range covers the measured number.
By their numbers in this assay, from the lowest: compounds 3, 1, 4 and 2 (each within the scatter of the next, the first and the last beyond it).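

In this assay, going by these compounds alone, the first change at this position, methoxycarbonyl to ethoxycarbonyl, gives a 1.6-fold higher number from compound 3 to compound 4 (0.20 log units; within the scatter), so the added methyl leaves the two compounds indistinguishable in this assay. The new compound also cannot be separated from either of the others: the readings are a 1.3-fold higher number from compound 1 to compound 4 (0.11 log units; within the scatter) and a 1.6-fold lower number from compound 2 to compound 4 (0.21 log units; within the scatter), whereas a 2.6-fold lower number from compound 2 to compound 3 (0.42 log units; beyond the scatter) did clear the scatter, so the clear separation from the free amine seen with the methoxycarbonyl compound does not carry over to its ethoxycarbonyl partner, even though the two esters themselves cannot be told apart. No supporting measurement is available to explain these small differences.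

The compounds shown leave open whether a longer chain on the ester oxygen, such as propyl or butyl, or a bulkier one such as benzyl, would produce a step that clears the scatter. They also leave open what happens when the ester itself is replaced, for example by a carboxylic acid or a primary amide on the same carbonyl carbon.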